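A few compounds are considered here, and "the series" means these few. Any claim that something is new, unique, unknown or untested is made for them only; others in the source may bear on it.

Of the compounds shown here, three built on one shared core have been tested in a functional assay on NALM-6 cells (Homo sapiens) for antiproliferative activity, read by MTT assay and trypan blue exclusion, with a stated time of 72 h; on this read-out higher numbers stand for weaker inhibition and lower numbers for stronger inhibition. Compound 1 `COC(=O)c1ccc(C2SCC(=O)N2c2ccc(N3CCN(Cc4cccc([N+](=O)[O-])c4)CC3)cn2)c(OC)c1` carries a 3-nitrobenzyl group on an amine nitrogen in a ring; in this assay compound 1 reaches only the limit > 100000 nM. Compound 2 `COC(=O)c1ccc(C2SCC(=O)N2c2ccc(N3CCN(S(=O)(=O)c4ccc(F)cc4)CC3)cn2)c(OC)c1` bears a (4-fluorophenyl)sulfonyl group on an amine nitrogen in a ring; in this assay compound 2 likewise gives only the limit > 100000 nM. Compound 3 `COC(=O)c1ccc(C2SCC(=O)N2c2ccc(N3CCNCC3)cn2)c(OC)c1`, which has a hydrogen there, is the only one of the three with a measured number, giving 9710 nM in this assay. The steps of an at least 10-fold lower number from compound 1 to compound 3 (1.01 log units; beyond the scatter) and an at least 10-fold lower number from compound 2 to compound 3 (1.01 log units; beyond the scatter) both run the same way, while the step that the two limits leave unreadable from compound 1 to compound 2 cannot be read since both ends sit at the limit of > 100000 nM in this assay, at which 2 of the 3 values shown sit. Compound 4 `COC(=O)c1ccc(C2SCC(=O)N2c2ccc(N3CCN(S(=O)(=O)c4cc(Cl)ccc4Cl)CC3)cn2)c(OC)c1` differs from compound 3 by (2,5-dichlorophenyl)sulfonyl in place of hydrogen on an amine nitrogen in a ring. Given the arylsulfonyl step an at least 10-fold lower number from compound 2 to compound 3 (1.01 log units; beyond the scatter), compound 4 is expected to show a step of a 10-fold higher number from compound 3 to compound 4 (1.01 log units; beyond the scatter) toward weaker inhibition in this assay. Compound 4 is therefore estimated at 100000 nM, with a likely range from 30000 nM to 300000 nM, and a good chance that only a limit is reported.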

Compound 4, half-maximal inhibitory concentration: 27400 nM
Beside the measured number, compound 4's estimate is 3.6-fold (0.56 log units) above it; measured number outside the range, below it.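

In this assay, a (2,5-dichlorophenyl)sulfonyl group on this amine nitrogen costs some activity, with a 2.8-fold higher number from compound 3 to compound 4 (0.45 log units; beyond the scatter), yet compound 4 still gives a measured number, so an arylsulfonyl group here does not by itself push a compound to the limit. The aryl group on the sulfonyl sulfur also counts: 2,5-dichlorophenyl in place of 4-fluorophenyl gives an at least 3.6-fold lower number from compound 2 to compound 4 (0.56 log units; beyond the scatter), and the change away from 3-nitrobenzyl gives an at least 3.6-fold lower number from compound 1 to compound 4 (0.56 log units; beyond the scatter). The true sizes of these two steps stay unknown because each starts from a limit, not a number: the limit of > 100000 nM in this assay, at which 2 of the 4 values shown sit.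

On these data alone, it remains open whether a single chlorine on the phenyl ring would do the same as the two in compound 4. As far as these compounds go, it also remains open whether a small methyl, acetyl or methylsulfonyl group on this nitrogen would match or improve on the hydrogen of compound 3.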